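The compounds below may be only part of what the source reports. "The series", "measured", "known", "first", "only" and "open" are said of these compounds alone.

Measured compounds:
Compound 1, `C=CCNC(=C\C(=O)/C=C/c1ccc(O)c(OC)c1)/C=C/c1ccc(O)c(OC)c1`, gives > 25000 nM in a functional assay on Caco-2 cells (Homo sapiens) for inhibition, read by sulforhodamine B assay, with a stated time of 72 h (a lower number here means a stronger inhibitor, a higher number a weaker inhibitor), a limit of the assay rather than a number.
Compound 2, `CCC(C)NC(=C\C(=O)/C=C/c1ccc(O)cc1)/C=C/c1ccc(O)cc1`, gives 5800 nM.
Compound 3, `CC(C)CNC(=C\C(=O)/C=C/c1ccc(O)cc1)/C=C/c1ccc(O)cc1`, gives 18500 nM.

Compound 1 thus stands at the edge of this assay, at the limit of > 25000 nM in this assay, at which 1 of the 3 values shown sits. Compound 4, `COc1cc(/C=C/C(=O)/C=C(/C=C/c2ccc(O)c(OC)c2)NC2CCCCC2)ccc1O`, differs from compound 1 by cyclohexyl in place of allyl on an amine nitrogen. Among the compounds with values here, the only measured step on an amine nitrogen is a 3.2-fold higher number from compound 2 to compound 3 (0.50 log units; beyond the scatter), made on a different shared core and swapping one chain for another rather than a chain for a ring, so it bears only loosely here. Because compound 1 gives only > 25000 nM, no step size can be read from it. Compound 4 is expected to stay weak, near 20000 nM, with a range of 6000 nM to 60000 nM. The expected step is an at least 1.2-fold lower number from compound 1 to compound 4 (0.09 log units; that floor lies within the scatter), with a fair chance that this assay again reports only a limit.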

Compound 4, half-maximal inhibitory concentration: 5100 nM
Estimate against measurement, compound 4: 3.9-fold (0.59 log units) above; the measured number lies below the stated range.
By their numbers in this assay, from the lowest: compounds 4 and 2 (each within the scatter of the next); then compound 3. At a limit, above all of these: compound 1.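

On the amine nitrogen of the core of compound 1, a ring can take the place of a chain, and the number in this assay falls: the step is an at least 4.9-fold lower number from compound 1 to compound 4 (0.69 log units; beyond the scatter). Within the data shown here, the only earlier step at such a nitrogen swapped one chain for another, whereas here cyclohexyl gives a measured value where allyl gave only a limit. Compound 1 carries only a limit, so the full size of this step cannot be read: the limit of > 25000 nM in this assay, at which 1 of the 4 values shown sits.

From the compounds shown here alone, whether the ring itself matters or simply the larger group remains open. A straight hexyl chain and a cyclopentyl ring on this nitrogen are the comparisons that would separate the two.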